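Working notes: replacing the 2-chlorophenyl group of compound 2

A few compounds are considered here, and "the series" means these few. Any claim that something is new, unique, unknown or untested is made for them only; others in the source may bear on it.

In a functional assay on DU-145 cells (Homo sapiens) for cytotoxicity, read by sulforhodamine B assay, with a stated time of 48 h (on this read-out higher numbers stand for weaker inhibition and lower numbers for stronger inhibition), compound 1 `COc1ccc(C2=NO[C@]3(C2)C(=O)O[C@@H]2[C@H]3CC[C@H](C)[C@]3(O)C=CC(=O)[C@@]23C)cc1OC` gives 84000 nM, and compound 2 `C[C@H]1CC[C@@H]2[C@@H](OC(=O)[C@]23CC(c2ccccc2Cl)=NO3)[C@]2(C)C(=O)C=C[C@@]12O` gives 19000 nM. For the measured compounds named here, compound 2 therefore holds the lower of the only two numbers available and is the stronger inhibitor of the pair.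

The next compound is compound 3 `C[C@H]1CC[C@@H]2[C@@H](OC(=O)[C@]23CC(c2ccc(C#N)cc2)=NO3)[C@]2(C)C(=O)C=C[C@@]12O`, with 4-cyanophenyl in place of 2-chlorophenyl on a carbon with a double bond to nitrogen. The shared core is unchanged.

Going by the values given here, one measured step bears on this change: a 4.4-fold lower number from compound 1 to compound 2 (0.65 log units; beyond the scatter), with 2-chlorophenyl in place of 3,4-dimethoxyphenyl on the same carbon. That step is modest, and a single step shows no trend. Neither measured compound carries a nitrile, so the data give no direct reading for this group.

With compound 2 at the low end of the two numbers, a small move towards a higher number is expected in this assay, no larger than the measured step. The expected change is a 1.6-fold higher number from compound 2 to compound 3 (0.20 log units; within the scatter). Compound 3 is estimated at 30000 nM, with an expected range of 9000 nM to 90000 nM.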

Compound 3, half-maximal inhibitory concentration: 26000 nM
Beside the measured number, compound 3's estimate is 1.2-fold (0.06 log units) above it; the measured number falls inside the stated range.
By their numbers in this assay, from the lowest: compounds 2 and 3 (each within the scatter of the next); then compound 1.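

The exchange of 2-chlorophenyl for 4-cyanophenyl, on the carbon with a double bond to nitrogen, gives a 1.4-fold higher number from compound 2 to compound 3 (0.14 log units; within the scatter) in this assay, so the two groups cannot be told apart at this position on the present numbers. The change from 3,4-dimethoxyphenyl to 4-cyanophenyl gives a 3.2-fold lower number from compound 1 to compound 3 (0.51 log units; beyond the scatter) on the shared core, so the gap to compound 1 no longer rests on 2-chlorophenyl alone: among these three compounds, the two without methoxy groups, compound 2 and compound 3, both carry lower numbers than compound 1, and neither goes against this limited pattern. The data hold no measurement that accounts for either step.

All three groups shown at this position are substituted phenyl rings, and their numbers span a narrow band, so it stays open whether this position can move the number much further. Also open, going by these compounds, is how a phenyl ring carrying an amine or a carboxylic acid, an unsubstituted phenyl ring, or a longer alkyl chain in place of the ring would read in the same assay.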